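Cytotoxicity notes: urea in place of aryl amide

The compounds below may be only part of what the source reports. "The series", "measured", "known", "first", "only" and "open" are said of these compounds alone.

Compound 1 `CN(C)c1cc2[nH]c(C3CCCCC3)nc2cc1NC(=O)c1ccc(C(C)(C)C)cc1` is tested in an ADME assay on Vero cells (Chlorocebus sabaeus) for cytotoxicity, read by resazurin assay, with a stated time of 3 days; on this read-out higher numbers stand for weaker inhibition and lower numbers for stronger inhibition; there compound 1 gives > 100 ug/mL, which is a limit of the assay and not a number. Compound 2 `CN(C)c1cc2[nH]c(C3CCCCC3)nc2cc1NC(=O)c1cccs1` in this assay gives > 100 ug/mL, again only a limit. Compound 3 `CCc1ccc(C(=O)Nc2cc3nc(C4CCCCC4)[nH]c3cc2N(C)C)cc1` in this assay gives > 100 ug/mL, also a limit. Among the measured compounds shown here, compound 3 therefore stands where every value so far sits, at the limit of > 100 ug/mL in this assay, at which 3 of the 3 values shown sit. The steps a step that the two limits leave unreadable from compound 1 to compound 2, a step that the two limits leave unreadable from compound 1 to compound 3 and a step that the two limits leave unreadable from compound 2 to compound 3 are all unreadable. Compound 4 `CCCCNC(=O)Nc1cc2nc(C3CCCCC3)[nH]c2cc1N(C)C` differs from compound 3 by butylamino in place of 4-ethylphenyl on a carbonyl carbon. For the measured compounds named here, no measured step reads on this change, so nothing beyond the scatter is foreseen. Compound 4 is expected to give 100 ug/mL, with a range from 50 ug/mL to 200 ug/mL. The step of a number no higher from compound 3 to compound 4 (the limit leaves the size open) is thus estimated to stay within the scatter, most likely again as a limit.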

Compound 4, half-maximal inhibitory concentration: > 100 ug/mL
Compound 4 gave a limit, no number (the forecaster's own chance of this, stated with the estimate: 80%); the middle value sits exactly at the limit.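

In this assay compound 4 gives > 100 ug/mL as a limit and not a number, so its steps from compound 1, compound 2 and compound 3 cannot be read. The compounds shown leave open what number any of them would give in this assay and whether butylamino on the carbonyl carbon changes it.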